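A few compounds are considered here, and "the series" means these few. Any claim that something is new, unique, unknown or untested is made for them only; others in the source may bear on it.

Working notes on a set of pyrazole-linked compounds carrying a nitrile-bearing chain, all tested in a functional assay on OVCAR-8 cells (Homo sapiens) for inhibition, read by sulforhodamine B assay, with a stated time of 48 h; on this read-out lower numbers stand for stronger inhibition of growth and higher numbers for weaker inhibition of growth. Compound 1 `COc1cc(C)cc(-c2c(-c3ccnc(-c4ccc(C(C)=O)cc4)c3)cnn2CC#N)c1` gives 2860 nM. Compound 2 `COc1cc(C)cc(-c2nn(CC#N)cc2-c2ccc(-c3cccc(C(C)=O)c3)nc2)c1` gives 3160 nM. Compound 3 `Cc1cc(O)cc(-c2nn(CC#N)cc2-c2ccnc(-c3ccc(Oc4ccccc4)cc3)c2)c1` gives 2080 nM, the lowest of the three numbers, although its gaps to compound 1 and to compound 2 both lie within the scatter, so no order among the three can be read from these values.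

Compound 4 `Cc1cc(O)cc(-c2nn(CC#N)cc2-c2ccnc(-c3ccc(N(C)C)cc3)c2)c1` has not yet been measured. It differs from compound 3 by dimethylamino in place of phenoxy on an aromatic carbon. Within the data shown here, no measured pair shows this kind of exchange, so there is no step to lean on. The step expected from compound 3 to compound 4 is a 1.2-fold higher number from compound 3 to compound 4 (0.08 log units; within the scatter), not beyond the scatter in either direction. Compound 4 is estimated at 2500 nM, within 1000 nM to 6500 nM.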

Compound 4, concentration for 50% growth inhibition: 4200 nM
The estimate for compound 4 lay 1.7-fold (0.23 log units) below the measured number; the measured number falls inside the stated range.
By their numbers in this assay, from the lowest: compounds 3, 1, 2 and 4 (each within the scatter of the next, the first and the last beyond it).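

In this assay, among these compounds, the exchange of phenoxy for dimethylamino, para to a large group, gives the only single-place step, and a 2.0-fold higher number from compound 3 to compound 4 (0.31 log units; beyond the scatter) shows that this position responds to its substituent, though modestly. Here a ringed group gives way to a smaller group without a ring, and the number rises. No supporting measurement bears on this result.

This one pair cannot separate loss of the ring from the entry of nitrogen. Going by these compounds, whether morpholine or benzyloxy at this carbon would follow phenoxy or dimethylamino remains open.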